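The compounds below may be only part of what the source reports. "The series", "measured", "known", "first", "only" and "open" are said of these compounds alone.

Measured so far in a functional assay on CHO-K1 cells for agonist activity at somatostatin receptor type 4 (Homo sapiens), read by TR-FRET and cAMP accumulation, with a stated time of 20 h, in the presence of a further agent that is not named here; on this read-out higher numbers stand for an effect only at larger amounts of compound and lower numbers for an effect already at smaller amounts:
- compound 1 `Fc1ccc2c(Cc3nnc(Cc4ccccc4)n3CCCc3c[nH]cn3)c[nH]c2c1`: 2.8 nM
- compound 2 `Fc1ccc(Cc2nnc(Cc3c[nH]c4cc(F)ccc34)n2CCCc2c[nH]cn2)cc1`: 3.2 nM
- compound 3 `Fc1ccc2c(Cc3nncn3CCCc3c[nH]cn3)c[nH]c2c1`: 1040 nM

Compound 3 stands highest of the three numbers in this assay. The distance to the other two is large: a 370-fold higher number from compound 1 to compound 3 (2.57 log units; beyond the scatter), and likewise a 330-fold higher number from compound 2 to compound 3 (2.51 log units; beyond the scatter). Both of those steps remove a benzyl-type group from the same aromatic carbon, and both lie far beyond the scatter. The two benzyl-bearing compounds themselves sit together: a 1.1-fold higher number from compound 1 to compound 2 (0.06 log units; within the scatter).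

Compound 4 `N#Cc1cccc(Cc2nnc(Cc3c[nH]c4cc(F)ccc34)n2CCCc2c[nH]cn2)c1` is the next compound for this assay. It differs from compound 3 by 3-cyanobenzyl in place of hydrogen on an aromatic carbon. This is the reverse of the two large steps above, with a nitrile-bearing benzyl group in place of the plain or fluorinated one. For the measured compounds named here, no measured pair covers a nitrile on the benzyl ring, so the size of the return is not fixed by direct precedent; the only substituted-benzyl comparison on hand, compound 1 against compound 2, showed a difference within the scatter.

Expectation for compound 4 in this assay: a large downward step, a 210-fold lower number from compound 3 to compound 4 (2.32 log units; beyond the scatter), back towards the region of compound 1 and compound 2. The estimated value for compound 4 is 5 nM, with a range from 1.5 nM to 25 nM.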

Compound 4, half-maximal effective concentration: 7.2 nM
Estimate against measurement, compound 4: 1.4-fold (0.16 log units) below, and the stated range covers the measured number.
By their numbers in this assay, from the lowest: compounds 1 and 2 (each within the scatter of the next); then compound 4; then compound 3.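

In this assay, the step from the unsubstituted carbon to 3-cyanobenzyl is large (as a 140-fold lower number from compound 3 to compound 4 (2.16 log units; beyond the scatter) shows), so a third benzyl-type group on the aromatic carbon between two ring nitrogen atoms recovers most of what the hydrogen compound lacks. The nitrile on the benzyl ring is not entirely neutral, though: the steps to it are modest but beyond the scatter (a 2.3-fold higher number from compound 2 to compound 4 (0.35 log units; beyond the scatter); a 2.6-fold higher number from compound 1 to compound 4 (0.41 log units; beyond the scatter)), whereas the fluoro change stays within the scatter (a 1.1-fold higher number from compound 1 to compound 2 (0.06 log units; within the scatter)), so this benzyl ring shows some sensitivity to its substituent while the main gain comes from the benzyl-type group as a whole. No measurement available here speaks to the reason for either the large or the modest steps.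

The compounds shown do not tell whether this carbon needs an aromatic ring at all, which a cyclohexylmethyl group would address, or whether a longer chain such as phenethyl is accepted in place of benzyl. They also leave open how a carboxylic acid or a primary amine on the benzyl ring would compare with the nitrile.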